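Swapping 2-phenylethenyl for 2-chlorophenyl on the shared core

The compounds below may be only part of what the source reports. "The series", "measured", "known", "first", "only" and "open" are said of these compounds alone.

Measured in a functional assay on CAPAN-1 cells (Homo sapiens) for antiproliferative activity, with a stated time of 72 h; a higher number here means a weaker inhibitor, a lower number a stronger inhibitor:
- compound 1 `Nc1ncnn2c([C@@H]3O[C@H](CO)[C@@H](O)[C@H]3O)cc(-c3ccc(F)cc3)c12`: 65600 nM
- compound 2 `Nc1ncnn2c([C@@H]3O[C@H](CO)[C@@H](O)[C@H]3O)cc(/C=C/c3ccccc3)c12`: 2600 nM

Compound 2, at 2600 nM, holds the lower of the two numbers. Compound 3 `Nc1ncnn2c([C@@H]3O[C@H](CO)[C@@H](O)[C@H]3O)cc(-c3ccccc3Cl)c12` has 2-chlorophenyl in place of 2-phenylethenyl on an aromatic carbon. Among the compounds with values here, one measured step bears on this: a 25-fold lower number from compound 1 to compound 2 (1.40 log units; beyond the scatter), large and beyond the scatter. It is the reverse kind of swap, from 4-fluorophenyl to 2-phenylethenyl. A large move to a higher number in this assay is therefore expected, though the different phenyl substituent leaves its size uncertain. The expected change is a 9.6-fold higher number from compound 2 to compound 3 (0.98 log units; beyond the scatter). Compound 3 is estimated at 25000 nM, with a range of 5000 nM to 100000 nM.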

Compound 3, half-maximal inhibitory concentration: 54900 nM
Compound 3: the middle estimate sits 2.2-fold (0.34 log units) below what was measured; the measured number falls inside the stated range.
By their numbers in this assay, from the lowest: compound 2; then compounds 3 and 1 (each within the scatter of the next).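

In this assay, 2-chlorophenyl in place of 2-phenylethenyl on the aromatic carbon reverses the earlier gain (a 21-fold higher number from compound 2 to compound 3 (1.32 log units; beyond the scatter)). The two substituted phenyl groups do not separate at this position (2-chlorophenyl in place of 4-fluorophenyl: a 1.2-fold lower number from compound 1 to compound 3 (0.08 log units; within the scatter)), so among these three compounds only 2-phenylethenyl stands apart. No available evidence accounts for this difference.

Still open, as far as these compounds go, is whether the double bond matters, which a saturated 2-phenylethyl chain would test. Also open, from the compounds shown here alone, is how an unsubstituted phenyl or an amine would read at this carbon.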